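The source may hold more compounds than are shown below. What is called first, only, known or untested is meant among the compounds shown, and "the series" means these compounds.

- Compound 1 `COc1cc(C(=O)c2ccc(OC)c(O)c2OC)cc(OC)c1O` gives 1900 nM in growth inhibition
- Compound 2 `COc1cc(C(=O)c2ccc3c(c2)oc(=O)n3S(C)(=O)=O)cc(OC)c1OC` gives 2640 nM in growth inhibition

In a functional assay on CAKI-1 cells (Homo sapiens) for cytotoxicity, read by sulforhodamine B assay, with a stated time of 48 h (on this read-out lower numbers stand for stronger inhibition of growth and higher numbers for weaker inhibition of growth), compound 1 at 1900 nM and compound 2 at 2640 nM lie within the usual scatter of each other, so compound 1 has no clear rank. Compound 3 `COc1ccc(C(=O)c2cc(OC)c(OC)c(OC)c2)c(OC)c1O` differs from compound 1 by methyl in place of hydrogen on an oxygen on an aromatic ring as methyl in place of hydrogen on an oxygen on an aromatic ring, hydroxy to methoxy. Among the measured compounds shown here, no measured step covers this change, so the expectation in this assay is loose: a moderate shift towards stronger inhibition of growth. The estimated size is a 3.2-fold lower number from compound 1 to compound 3 (0.50 log units; beyond the scatter) and remains uncertain. For compound 3 the estimated value is 600 nM with an expected range from 80 nM to 3000 nM in this series.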

Compound 3, concentration for 50% growth inhibition: 120 nM
The estimate for compound 3 lay 5.0-fold (0.70 log units) above the measured number; the range from low to high includes it.
By their numbers in this assay, from the lowest: compound 3; then compounds 1 and 2 (each within the scatter of the next).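

In this assay, replacing hydroxy with methoxy at this position gives a 16-fold lower number from compound 1 to compound 3 (1.20 log units; beyond the scatter), a large step for a single added methyl. The hydrogen on this oxygen is therefore not required for growth inhibition in this pair, and the position is sensitive to substitution. No available measurement bears on the reason for the size of this step.

Going by these compounds, whether ethoxy, a longer chain or an amine at this position would keep the gain remains open. Also open, on these data alone, is how the same change would act on the other hydroxy, which compound 3 retains.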